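A few compounds are considered here, and "the series" means these few. Any claim that something is new, unique, unknown or untested is made for them only; others in the source may bear on it.

Of the compounds shown here, two built on a shared core have been measured so far in an ADME assay for permeability, using PAMPA, at pH 7.4; a higher number here means that the compound crosses the layer faster, a lower number that the compound crosses the layer more slowly. Compound 1 `Cc1cc(NC(=O)Nc2ccc(SC(F)(F)F)cc2)c2ccccc2n1` gives 206 10^-6 cm/s, and compound 2 `Cc1cc(NC(=O)Nc2ccc(N)cc2)c2ccccc2n1` gives 530 10^-6 cm/s, the higher of the two numbers. Among the measured compounds shown here, the one measured step, a 2.6-fold higher number from compound 1 to compound 2 (0.41 log units; beyond the scatter), puts amino in place of (trifluoromethyl)sulfanyl on an aromatic carbon; it is modest but beyond the scatter. Compound 3 `COc1ccc(NC(=O)Nc2cc(C)nc3ccccc23)cc1` has methoxy in place of amino on an aromatic carbon, para to a large group (methoxy in place of amino on an aromatic carbon). For the measured compounds named here, that single step is the only guide, and it involves a different incoming group, so it bears on this change only loosely. Compound 1, at 206 10^-6 cm/s, shows that losing amino lowered the number once, so a smaller drop in the same direction is expected here, possibly within the scatter. The expected step is a 1.5-fold lower number from compound 2 to compound 3 (0.18 log units; within the scatter). Compound 3 is estimated at 350 10^-6 cm/s, within a range of 160 10^-6 cm/s to 700 10^-6 cm/s.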

Compound 3, apparent permeability: 787 10^-6 cm/s
Estimate against measurement, compound 3: 2.2-fold (0.35 log units) below; the whole stated range lies below it.
By their numbers in this assay, from the lowest: compound 1; then compounds 2 and 3 (each within the scatter of the next).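

Putting methoxy in place of amino on this aromatic carbon, para to a large group, removes a hydrogen-bond donor, yet in this assay the result (a 1.5-fold higher number from compound 2 to compound 3 (0.17 log units; within the scatter)) leaves the two groups indistinguishable. Compared with (trifluoromethyl)sulfanyl at the same place, methoxy gives a modest step beyond the scatter (a 3.8-fold higher number from compound 1 to compound 3 (0.58 log units; beyond the scatter)), much like the earlier step to amino, so here (trifluoromethyl)sulfanyl alone stands apart from the other two groups. Among the compounds shown here, nothing measured so far explains why these steps have the sizes they do.

For the compounds shown here, with only three groups compared at this one place, no general rule for the position can be drawn. As far as these compounds go, it remains open whether a carboxylic acid, a nitrile or a longer chain such as ethoxy would stay level with amino and methoxy or fall towards compound 1.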